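This account rests on a few compounds, and the source may have more. Where it says the series, first, only, none or still open, it means among the compounds named here.

Measured so far in a functional assay on HepG2 cells (Homo sapiens) for antiproliferative activity, read by MTT assay; a lower number here means a stronger inhibitor, a higher number a weaker inhibitor:
compound 1 `Nc1c(C(=O)N/N=C/c2ccccc2)oc2nc(-c3ccccc3)cc(C(F)(F)F)c12` gives 13100 nM
compound 2 `Nc1c(C(=O)N/N=C/c2ccc(Cl)cc2)oc2nc(-c3cccs3)cc(C(F)(F)F)c12` gives 8100 nM
compound 3 `Nc1c(C(=O)N/N=C/c2ccc(Cl)cc2)oc2nc(-c3ccccc3)cc(C(F)(F)F)c12` gives 12100 nM

Compound 2 stands level with the other two compounds. The step of a 1.5-fold higher number from compound 2 to compound 3 (0.17 log units; within the scatter) is small, and the values of compound 1 and compound 2 also lie within the scatter of each other. So these three numbers form one group, with no clear leader.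

Still unmeasured is compound 4 `CCCNC(=O)c1oc2nc(-c3cccs3)cc(C(F)(F)F)c2c1N`, which keeps the shared core of compound 2. The change is larger than any measured so far: a group of 3 heavy atoms (3 carbon; no ring) in place of a group of 9 heavy atoms (7 carbon, 1 nitrogen, 1 chlorine; one six-membered aromatic ring of carbon only), on an amide-type nitrogen. The entering group is a plain propyl.

Going by the values given here, two measured steps bear on this, both only indirectly. The step of a 1.1-fold lower number from compound 1 to compound 3 (0.03 log units; within the scatter) adds chloro to the aromatic ring of the group that leaves, and it changes little. The step of a 1.5-fold higher number from compound 2 to compound 3 (0.17 log units; within the scatter) swaps the aromatic group on the core, and it changes little too. Among the compounds with values here, no measured pair replaces the whole group on the amide-type nitrogen, so the data do not show what such a swap does.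

With only these small steps to go on, no step beyond the scatter is expected in this assay, though this expectation is weak. The estimated step is a 1.5-fold higher number from compound 2 to compound 4 (0.17 log units; within the scatter) for now. For compound 4 the estimated value is 12000 nM, with an expected range from 4000 nM to 40000 nM.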

Compound 4, half-maximal inhibitory concentration: 17200 nM
The estimate for compound 4 lay 1.4-fold (0.16 log units) below the measured number; low and high end bracket the measured number.
By their numbers in this assay, from the lowest: compounds 2, 3, 1 and 4 (each within the scatter of the next, the first and the last beyond it).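

In this assay, going by these compounds alone, replacing the whole group on the amide-type nitrogen with a plain propyl gives a 2.1-fold higher number from compound 2 to compound 4 (0.33 log units; beyond the scatter), the only step in this set that lies beyond the scatter, though it is modest. By contrast, adding chloro to the aromatic ring of that group gives a 1.1-fold lower number from compound 1 to compound 3 (0.03 log units; within the scatter), so this small edit to the group leaves the number within the scatter, while exchanging the whole group moves it measurably. Even so, compound 4, with no ring in this group, still gives a finite number of 17200 nM, so in this one pair the aromatic ring is not needed for a readable result, and nothing available says which part of the departing group accounts for the step.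

Going by these compounds, it remains open whether a longer chain, a benzyl group or a chain ending in an amine at this nitrogen would give a number closer to that of compound 2 or further from it. Also open, on these data alone, is whether the propyl would produce a similar step with phenyl in place of thiophen-2-yl on the shared core.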